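The source may report more compounds than this note shows. Statements on the series, on what has been measured and on what is new or still open speak of the compounds shown alone.

Measured in a functional assay on DU-145 cells (Homo sapiens) for cytotoxicity, read by MTT assay; a lower number here means a stronger inhibitor, a higher number a weaker inhibitor:

- Compound 1 `CC(=O)OCCC(=O)O[C@H](CC=C(C)C)C1=CC(=O)c2c(O)ccc(O)c2C1=O`: 15700 nM
- Compound 2 `CC(=O)OCCO[C@H](CC=C(C)C)C1=CC(=O)c2c(O)ccc(O)c2C1=O`: 15500 nM
- Compound 3 `COCCO[C@H](CC=C(C)C)C1=CC(=O)c2c(O)ccc(O)c2C1=O`: 43200 nM

Compound 3, at 43200 nM, has the highest number of the three and is the weakest, since its steps to both others lie beyond the scatter. Compound 4 `CCC(CO[C@H](CC=C(C)C)C1=CC(=O)c2c(O)ccc(O)c2C1=O)OC(C)=O` differs from it at one place, where 2-acetoxybutyl stands in place of 2-methoxyethyl: 1-acetoxypropyl in place of methoxymethyl on a saturated chain carbon bound to an oxygen on a saturated carbon. The closest measured evidence is the exchange of acetyl for methyl, seen in a 2.8-fold higher number from compound 2 to compound 3 (0.45 log units; beyond the scatter), a modest step. Compound 4 carries an acetoxy group again, so that step would be expected to run in reverse. The step of a 2.8-fold higher number from compound 1 to compound 3 (0.44 log units; beyond the scatter) is of similar size, whereas a 1.0-fold lower number from compound 1 to compound 2 (0.01 log units; within the scatter) stays within the scatter. Among these three compounds, both acetoxy-bearing ones have lower numbers than the methoxy compound, and none goes against this. Among the compounds with values here, no measured step covers the longer 2-acetoxybutyl chain itself, so the range is kept wide. A modest fall in the number is therefore expected in this assay. For compound 4 the estimate is 15000 nM, with an expected range from 6500 nM to 33000 nM. The estimated step is a 2.9-fold lower number from compound 3 to compound 4 (0.46 log units; beyond the scatter).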

Compound 4, half-maximal inhibitory concentration: 25400 nM
Compound 4: middle estimate off by 1.7-fold (0.23 log units), on the low side; the measured number falls inside the stated range.
By their numbers in this assay, from the lowest: compounds 2, 1, 4 and 3 (each within the scatter of the next, the first and the last beyond it).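

In this assay, the exchange of 2-methoxyethyl for 2-acetoxybutyl stays within the scatter (a 1.7-fold lower number from compound 3 to compound 4 (0.23 log units; within the scatter)), so compound 4 does not share the separation from compound 3 that compounds 1 and 2 show, and it goes against any clean split between acetoxy-bearing and methoxy-bearing chains at this position. The ethyl group in place of hydrogen on the saturated chain carbon also stays within the scatter (a 1.6-fold higher number from compound 2 to compound 4 (0.21 log units; within the scatter)), as does the exchange of (2-acetoxyethyl)carbonyl for 2-acetoxybutyl (a 1.6-fold higher number from compound 1 to compound 4 (0.21 log units; within the scatter)), so compound 4 cannot be told apart from any of the other three, and the added ethyl shows no resolved change on this chain. Nothing given here bears on the reason for these numbers.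

The compounds shown leave open whether the acetoxy group itself matters on this chain, which a free hydroxyl on the same carbon could test, and whether a methyl or a propyl in place of the ethyl would behave alike. They also leave open how a longer chain, or an amine at the end of the ethyl chain, would fare at this oxygen.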